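Methyl in Place of Chloro on the Pendant Phenyl

A few compounds are considered here, and "the series" means these few. Any claim that something is new, unique, unknown or untested is made for them only; others in the source may bear on it.

Compound 1, `CS(=O)(=O)c1ccc(-c2cnc3[nH]cc(-c4nnc(-c5ccc(F)cc5)o4)c(=O)c3c2)cc1`: 9.45%
Compound 2, `CS(=O)(=O)c1ccc(-c2cnc3[nH]cc(-c4nnc(-c5ccc(Cl)cc5)o4)c(=O)c3c2)cc1`: 11.3%

Both compounds were tested in a functional assay on HepG2 cells (Homo sapiens) for inhibition, read by MTT assay, with a stated time of 24 h, tested at 5 uM; on this read-out lower numbers stand for less inhibition of growth and higher numbers for more inhibition of growth at the one concentration tested. Compound 2 gives 11.3%, the higher of the two numbers on paper, but the step of a number 1.9 percentage points higher from compound 1 to compound 2 (within the scatter) lies within the scatter, so compound 1 and compound 2 are not truly separated.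

Compound 3, `Cc1ccc(-c2nnc(-c3c[nH]c4ncc(-c5ccc(S(C)(=O)=O)cc5)cc4c3=O)o2)cc1`, has not yet been measured. It differs from compound 2 by methyl in place of chloro on an aromatic carbon. Within the data shown here, the one measured step that touches the same place, a number 1.9 percentage points higher from compound 1 to compound 2 (within the scatter), swapped one halogen for another and changed nothing beyond the scatter. Among the measured compounds shown here, a methyl in that place has no measured precedent here, so the expectation rests on that single small step: compound 3 is expected to show a number 0.3 percentage points lower from compound 2 to compound 3 (within the scatter), with no step beyond the scatter in either direction. The estimate for compound 3 in this assay is 11%, ranging from 0% to 25%.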

Compound 3, percent growth inhibition at one concentration: 6.9%
Compound 3: the middle estimate sits 4.1 percentage points above what was measured; the measured number falls inside the stated range.
By their numbers in this assay, from the lowest: compounds 3, 1 and 2 (each within the scatter of the next).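

The earlier pair showed only one halogen exchanged for another on this phenyl ring, whereas compound 3 puts a carbon group in that place. In this assay this replacement of a halogen by methyl separates nothing: the chloro compound gives way to the methyl compound with little effect (a number 4.4 percentage points lower from compound 2 to compound 3 (within the scatter)), and the comparison with the fluoro compound reads the same way (a number 2.6 percentage points lower from compound 1 to compound 3 (within the scatter)). So fluoro, chloro and methyl in this place cannot be told apart on this read-out, and no information is available to explain the numbers.

On these data alone, whether any group here can move the number beyond the scatter remains open, for instance an amine, a carboxylic acid or a longer chain such as butyl. Plain hydrogen in this place would give a further useful reference.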